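Phenyl in Place of 5-Fluoropyrimidin-2-yl: Cytotoxicity Outlook

The source may report more compounds than this note shows. Statements on the series, on what has been measured and on what is new or still open speak of the compounds shown alone.

Compound 1, `C[C@H]1Cn2ncc(N3CC(c4ccccc4)CC3=O)c2CN1S(=O)(=O)Nc1cc(F)c(F)c(F)c1`: > 2000 nM
Compound 2, `O=C1CC(c2ncc(F)cn2)CN1c1cnn2c1CN(C(=O)Nc1cc(F)c(F)c(F)c1)C(C1CC1)C2`: 115000 nM
Compound 3, `C[C@H]1Cn2ncc(N3CC(c4ccccc4)CC3=O)c2CN1C(=O)Nc1cc(F)c(F)c(F)c1`: 12800 nM

In a toxicity assay on HepG2 2.2.15 cells (Homo sapiens) for cytotoxicity, read by CellTiter-Glo (a lower number here means that less compound is tolerated, a higher number that more compound is tolerated), compound 2 gives 115000 nM, the highest of the two numbers given; compound 3 gives 12800 nM, a gap beyond the scatter. For compound 1 this assay reports only a limit, > 2000 nM, and no number. Compound 4, `O=C1CC(c2ccccc2)CN1c1cnn2c1CN(C(=O)Nc1cc(F)c(F)c(F)c1)C(C1CC1)C2`, is not yet measured in this assay. It differs from compound 2 in one place: phenyl in place of 5-fluoropyrimidin-2-yl on a saturated ring carbon. Among the compounds with values here, no measured pair shows this change on its own. Compound 4 is expected to give 40000 nM, with a range from 12000 nM to 120000 nM, because compound 3, which also carries phenyl, gives 12800 nM. The step from compound 2 to compound 4 is thus estimated at a 2.9-fold lower number from compound 2 to compound 4 (0.46 log units; beyond the scatter), a lower number beyond the scatter.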

Compound 4, half-maximal cytotoxic concentration: 12800 nM
For compound 4 the middle estimate is 3.1-fold (0.49 log units) above the measured one; low and high end bracket the measured number.
By their numbers in this assay, from the lowest: compounds 3 and 4 (each within the scatter of the next); then compound 2.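

In this assay the saturated ring carbon, two ring bonds from the ring nitrogen, proves sensitive to which aromatic ring it carries: the change gives a 9.0-fold lower number from compound 2 to compound 4 (0.95 log units; beyond the scatter). Within the data shown here, no earlier pair isolated this change, so this is the first direct reading of it at this position. Nothing in the data at hand accounts for the step. From the compounds shown here alone, it remains open how a fluorophenyl group would read here, and whether it would stand with compound 4 or with compound 2. Going by these compounds, an amine or a carboxylic acid on this ring carbon is equally open.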